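A few compounds are considered here, and "the series" means these few. Any claim that something is new, unique, unknown or untested is made for them only; others in the source may bear on it.

Working notes on the series built on the core of compound 1 `COc1cccc(CCC(=O)Nc2nc3ccccc3c(=O)s2)c1`. In an in vitro assay on cells for inhibition of Amine oxidase [flavin-containing] B (Homo sapiens), read by fluorescence and Amplex Red, with stated times of 30 min and 45 min (on this read-out lower numbers stand for stronger inhibition and higher numbers for weaker inhibition), compound 1 gives 95.3 nM, the lowest of the two numbers at hand. Compound 3 `COc1cccc(/C=C/C(=O)Nc2nc3ccccc3c(=O)s2)c1` gives 470 nM in this assay, a gap from compound 1 that lies beyond the scatter. For compound 2 `O=C(Nc1nc2ccccc2c(=O)s1)c1ccccc1` the result in this assay is "not determined" (no result reported). Compound 4 `O=C(CCCc1ccccc1)Nc1nc2ccccc2c(=O)s1` is not yet measured; it differs from compound 1 by benzyl in place of 3-methoxyphenyl on a saturated chain carbon, two bonds along the chain from a carbonyl carbon. Among the measured compounds shown here, no measured pair carries this change, so its size is not fixed by the data. The expected step is a 2.3-fold higher number from compound 1 to compound 4 (0.36 log units; beyond the scatter), a modest move toward weaker inhibition. For compound 4 the estimate in this assay is 220 nM, with a range from 70 nM to 700 nM.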

Compound 4, half-maximal inhibitory concentration: 34.9 nM
Compound 4: middle estimate off by 6.3-fold (0.80 log units), on the high side; measured number outside the range, below it.
By their numbers in this assay, from the lowest: compound 4; then compound 1; then compound 3.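

In this assay, benzyl in place of 3-methoxyphenyl on a saturated chain carbon, two bonds along the chain from a carbonyl carbon, gives a 2.7-fold lower number from compound 1 to compound 4 (0.44 log units; beyond the scatter). This position therefore accepts the change, and the hydrogen-bond acceptor counted in 3-methoxyphenyl is not needed to reach the lower number of compound 4. Nothing at hand explains the step. Open, as far as these compounds go, is how an amine, a carboxylic acid or a longer chain would read in this place. A methoxy group on benzyl would also test whether that group alone accounts for the step.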